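Trimming the Cyanoguanidine Tail: Compound 1 to Compound 4

This account rests on a few compounds, and the source may have more. Where it says the series, first, only, none or still open, it means among the compounds named here.

Compound 1 `CCC/N=C(/NC#N)NCCCCCn1nc(-c2ccccc2)ccc1=O`: > 100 mg/kg
Compound 2 `CC/N=C(/NC#N)NCCCn1nc(-c2ccccc2)ccc1=O`: 78.3 mg/kg
Compound 3 `C/N=C(\S)NCCCCn1nc(-c2ccccc2)ccc1=O`: 28.9 mg/kg

In a functional assay on the whole organism (stomach) with Rattus norvegicus as the target (a lower number here means that less compound is needed, a higher number that more compound is needed for the effect), compound 1 gives only a limit of the assay, > 100 mg/kg, so it stands at the limit of > 100 mg/kg in this assay, at which 1 of the 3 values shown sits, rather than at a number. Compound 2 gives 78.3 mg/kg in this assay. Compound 3 gives 28.9 mg/kg in this assay.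

Compound 4 `CN(C)/C(=N/CCCCCn1nc(-c2ccccc2)ccc1=O)NC#N` differs from compound 1 in one place: a group of 8 heavy atoms (4 carbon, 4 nitrogen; no ring) in place of a group of 9 heavy atoms (5 carbon, 4 nitrogen; no ring), on a saturated chain carbon, five bonds along the chain from an aromatic nitrogen. Going by the values given here, the only measured step, a 2.7-fold lower number from compound 2 to compound 3 (0.43 log units; beyond the scatter), exchanges a different group on a shorter chain and so does not bear on this change. With compound 1 known only as a limit, no step beyond the scatter is expected, and compound 4 is expected near that same limit. The estimate for compound 4 is 90 mg/kg, with a range from 30 mg/kg to 300 mg/kg. This estimate means an expected at least 1.1-fold lower number from compound 1 to compound 4 (0.04 log units; that floor lies within the scatter).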

Compound 4, dose for half-maximal effect: 81.5 mg/kg
Beside the measured number, compound 4's estimate is 1.1-fold (0.04 log units) above it; measured number inside the range.
By their numbers in this assay, from the lowest: compound 3; then compounds 2 and 4 (each within the scatter of the next). At a limit, above all of these: compound 1.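

Compound 1 is known only as a limit: the limit of > 100 mg/kg in this assay, at which 1 of the 4 values shown sits.

In this assay, the change on a saturated chain carbon, five bonds along the chain from an aromatic nitrogen, gives an at least 1.2-fold lower number from compound 1 to compound 4 (0.08 log units; that floor lies within the scatter). As far as these compounds go, this gives the chain in compound 4 a measured number, but the true size of the step stays unknown, and its floor shows no gain beyond the scatter.

From the compounds shown here alone, what a simple amine in this place would give remains open, as does the effect of a longer chain carrying the group of compound 4.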